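A few compounds are considered here, and "the series" means these few. Any claim that something is new, unique, unknown or untested is made for them only; others in the source may bear on it.

Compound 3 `COc1ccc(CS(=O)(=O)/C=C/c2ccc(Cl)cc2)cc1` and compound 1 `COc1cc(OC)c(/C=C/S(=O)(=O)Cc2ccc(Cl)cc2)c(OC)c1` each carry a chloro on an aromatic carbon at one end but differ in the rest of the molecule, and compound 2 `COc1cc(OC)c(/C=C/S(=O)(=O)Cc2ccc(C#N)cc2)c(OC)c1` carries a cyano where compound 1 carries its chloro. In a functional assay on DLD-1 cells (Homo sapiens) for antiproliferative activity, read by trypan blue exclusion (on this read-out higher numbers stand for weaker inhibition and lower numbers for stronger inhibition), compound 3 gives 3000 nM, the lowest number of the three and beyond the scatter from both of the others. In this assay compound 1 gives 15000 nM, and compound 2 gives 20000 nM. Within the data shown here, the only single-point comparison among the measured compounds is a 1.3-fold higher number from compound 1 to compound 2 (0.12 log units; within the scatter).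

Compound 4 `COc1ccc(CS(=O)(=O)/C=C/c2ccc(N)cc2)cc1` is obtained from compound 3 by amino in place of chloro on an aromatic carbon. Among the measured compounds shown here, the step from compound 1 to compound 2 is the only measured step that bears on this change, since it also replaces a chloro on the same kind of aromatic carbon, and it stayed within the scatter. Amino is a different kind of group from cyano, however, so that step is not a close match, and the expectation rests on thin ground. The step expected in this assay is a 1.2-fold higher number from compound 3 to compound 4 (0.07 log units; within the scatter), which is no change beyond the scatter. Compound 4 is therefore expected to give about 3500 nM, with a range from 1000 nM to 15000 nM.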

Compound 4, half-maximal inhibitory concentration: > 20000 nM
Compound 4: a limit, no number (the forecaster's own chance of this, stated with the estimate: 5%); middle value at least 5.7-fold (0.75 log units) away from the limit.
By their numbers in this assay, from the lowest: compound 3; then compounds 1 and 2 (each within the scatter of the next).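

The value of compound 4 is a limit of the assay and not a number: the limit of > 20000 nM in this assay, at which 1 of the 4 values shown sits. Even so, in this assay the step reads an at least 6.6-fold higher number from compound 3 to compound 4 (0.82 log units; beyond the scatter), so on this aromatic carbon, para to a large group, the chloro of compound 3 cannot be exchanged freely. Among these compounds, the only earlier exchange of a chloro, a 1.3-fold higher number from compound 1 to compound 2 (0.12 log units; within the scatter), brought in cyano on a different core and gave no change beyond the scatter, so this is the first sign that the group on such a carbon can decide how strongly a compound inhibits cell growth here.

From the compounds shown here alone, what remains open is whether the weaker inhibition belongs to the amino group itself or to the loss of the chloro, a question that a fluoro, a methyl or a hydroxyl on the same aromatic carbon would help to separate. The compounds shown also do not tell how far compound 4 lies beyond its limit, whether amino would act the same way on the core of compound 1, or why this change has the effect it has.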